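A few compounds are considered here, and "the series" means these few. Any claim that something is new, unique, unknown or untested is made for them only; others in the source may bear on it.

Compound 3 `Cc1ccc(/C=C/[C@@H]2CCCCN2)cc1` gives 8.56 ug/mL in a functional assay on A549 cells (Homo sapiens) for inhibition, read by MTT assay, with a stated time of 24 h (a lower number here means a stronger inhibitor, a higher number a weaker inhibitor), and stands second highest of the three numbers shown; compound 2 `C(=C/[C@@H]1CCCCN1)\c1ccccc1` gives 9.99 ug/mL and compound 1 `CCc1ccc(/C=C/[C@@H]2CCCCN2)cc1` gives 5.94 ug/mL. Compound 4 `COc1ccc(/C=C/[C@@H]2CCCCN2)cc1` is not yet measured; it differs from compound 3 by methoxy in place of methyl on an aromatic carbon. The steps seen at this place are all small: a 1.2-fold lower number from compound 2 to compound 3 (0.07 log units; within the scatter), a 1.7-fold higher number from compound 1 to compound 2 (0.23 log units; within the scatter) and a 1.4-fold higher number from compound 1 to compound 3 (0.16 log units; within the scatter). Among the measured compounds shown here, none of them is a direct precedent for a methoxy group, but every exchange at this place so far has stayed within the scatter, so a step of that order, with no clear direction, is expected here as well, a 1.1-fold lower number from compound 3 to compound 4 (0.03 log units; within the scatter). Compound 4 is therefore estimated at 8 ug/mL in this assay, with a range from 3.5 ug/mL to 18 ug/mL.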

Compound 4, half-maximal inhibitory concentration: 4.33 ug/mL
Compound 4: the middle estimate sits 1.8-fold (0.27 log units) above what was measured; the range from low to high includes it.
By their numbers in this assay, from the lowest: compounds 4, 1, 3 and 2 (each within the scatter of the next, the first and the last beyond it).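

In this assay, among the compounds shown here, the step of a 2.3-fold lower number from compound 2 to compound 4 (0.36 log units; beyond the scatter) is the first beyond the scatter at this place, though only a modest one. Against methyl and ethyl, the steps of a 2.0-fold lower number from compound 3 to compound 4 (0.30 log units; within the scatter) and a 1.4-fold lower number from compound 1 to compound 4 (0.14 log units; within the scatter) stay within the scatter, so methoxy stands apart only from hydrogen. No evidence on the origin of this step is at hand.

Open, from the compounds shown here alone, is whether the oxygen itself matters here, which a hydroxyl or ethoxy group on the same aromatic carbon would test. Going by these compounds, how an amine or a carboxylic acid would read at this place also remains open.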